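The source may hold more compounds than are shown below. What is called first, only, known or untested is meant among the compounds shown, and "the series" means these compounds.

Notes on the shared core carrying the glutamate amide side chain, measured in an assay on isolated protein for inhibition of Thymidylate synthase (Mus musculus); on this read-out higher numbers stand for weaker inhibition and lower numbers for stronger inhibition.

For the measured compounds named here, compound 2 `C#CCN(Cc1ccc2nc(C)[nH]c(=O)c2c1)c1ccc(C(=O)N[C@@H](CCC(=O)O)C(=O)O)c(F)c1` sits at the strong end of the three numbers known so far: in this assay compound 2 gives 20 nM. Going by the values given here, compound 3 `C#CCN(Cc1ccc2nc(C)[nH]c(=O)c2c1)c1ccc(C(=O)N[C@@H](CCC(=O)O)C(=O)O)c(C(F)(F)F)c1` gives 480 nM, and the only single-point step recorded, a 24-fold higher number from compound 2 to compound 3 (1.38 log units; beyond the scatter), concerns the substituent on the aromatic ring and not the chain on the nitrogen. Compound 1 `Cc1nc2ccc(CNc3ccc(C(=O)N[C@@H](CCC(=O)O)C(=O)O)cc3F)cc2c(=O)[nH]1` carries a hydrogen on that nitrogen in place of the propargyl of compound 2; in this assay compound 1 gives 9340 nM. Among the compounds with values here, no step is computed for that pair, so only the two values themselves are available.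

Compound 4 `CCN(Cc1ccc2nc(C)[nH]c(=O)c2c1)c1ccc(C(=O)N[C@@H](CCC(=O)O)C(=O)O)c(F)c1` differs from compound 2 by methyl in place of ethynyl on a saturated chain carbon bound to a nitrogen on an aromatic ring. Neither recorded step covers this change. The comparison of compound 1 with compound 2 shows that a large loss is possible when the chain on the nitrogen is lost entirely, while an ethyl keeps a chain there, so a moderate weakening is expected rather than a collapse. The expected step is a 3.0-fold higher number from compound 2 to compound 4 (0.48 log units; beyond the scatter), a higher number. Compound 4 is therefore estimated at 60 nM in this assay, with a range of 20 nM to 200 nM.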

Compound 4, half-maximal inhibitory concentration: 45 nM
For compound 4 the middle estimate is 1.3-fold (0.12 log units) above the measured one; measured number inside the range.
By their numbers in this assay, from the lowest: compound 2; then compound 4; then compound 3; then compound 1.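

In this assay, for the compounds shown here, the change from propargyl to ethyl on the nitrogen gives the first single-point step at this position: a 2.3-fold higher number from compound 2 to compound 4 (0.35 log units; beyond the scatter). The step is beyond the scatter, so the chain on the nitrogen does influence the read-out, but it is modest and much smaller than the large step at the aromatic substituent, a 24-fold higher number from compound 2 to compound 3 (1.38 log units; beyond the scatter); within this pair, the triple bond outside aromatic rings can be replaced by a fully saturated chain with only a small rise in the number, and compound 4 remains at 45 nM. No measurement available here accounts for this difference, so the step can be recorded but its origin cannot be assigned.

The compounds shown leave open how the read-out responds to other groups on the same nitrogen, such as a methyl, a longer propyl chain, an allyl or a hydroxyethyl chain, so the trend with chain length and saturation cannot yet be drawn from a single pair. From the compounds shown here alone, it also remains open whether trifluoromethyl in place of fluoro produces a step of similar size when ethyl, rather than propargyl, sits on the nitrogen.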